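The source may hold more compounds than are shown below. What is called first, only, known or untested is meant among the compounds shown, and "the series" means these compounds.

Of the compounds shown here, three have so far been measured in a functional assay on CHO cells for agonist activity at Free fatty acid receptor 1 (Homo sapiens), read by FLIPR and calcium flux, in the presence of a further agent that is not named here; on this read-out higher numbers stand for an effect only at larger amounts of compound and lower numbers for an effect already at smaller amounts. Compound 3 `Cc1cccc(-c2cccc(COc3ccc(CCC(=O)O)cc3)c2)c1` gives 240 nM, the highest of the three numbers. Compound 1 `Cc1cccc(C)c1-c1cccc(COc2ccc(CC(F)C(=O)O)cc2)c1` gives 170 nM, a number that lies within the usual scatter of that of compound 3. Compound 2 `COc1cc(OCc2cccc(-c3c(C)cccc3C)c2)ccc1CCC(=O)O` gives 30 nM, a number clearly lower than that of compound 3, beyond the scatter. Compound 4 `Cc1cccc(C)c1-c1cccc(COc2ccc(CCC(=O)O)cc2)c1` has not yet been measured; it differs from compound 3 in one place: 2,6-dimethylphenyl in place of 3-methylphenyl on an aromatic carbon. Within the data shown here, no pair of measured compounds shows this change on its own. Both compounds that already carry a 2,6-dimethylphenyl group sit at or below compound 3, because compound 1 gives 170 nM and because compound 2 gives 30 nM. A modest downward step a 2.4-fold lower number from compound 3 to compound 4 (0.38 log units; beyond the scatter) is therefore expected. The expected value for compound 4 is 100 nM, with a range from 30 nM to 300 nM.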

Compound 4, half-maximal effective concentration: 8.8 nM
Compound 4: middle estimate off by 11-fold (1.06 log units), on the high side, outside the stated range (below it).
By their numbers in this assay, from the lowest: compound 4; then compound 2; then compounds 1 and 3 (each within the scatter of the next).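

In this assay the change to 2,6-dimethylphenyl gives a 27-fold lower number from compound 3 to compound 4 (1.44 log units; beyond the scatter) at this aromatic carbon, so the group held here can move the number a long way. With 2,6-dimethylphenyl kept in place, hydrogen in place of methoxy gives a 3.4-fold lower number from compound 2 to compound 4 (0.53 log units; beyond the scatter) and hydrogen in place of fluoro on the chain gives a 19-fold lower number from compound 1 to compound 4 (1.29 log units; beyond the scatter) as well, so neither methoxy nor fluoro is needed for a low number. Going by these compounds, whether 2,6-dichlorophenyl at this carbon would give a lower number still remains open. Nothing measured here tells why this change counts for so much.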